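This account rests on a few compounds, and the source may have more. Where it says the series, first, only, none or still open, it means among the compounds named here.

Measured so far:
Compound 1, `COc1ccc(CN2CCCN(Cc3ccccc3)[C@H](C)C2)cc1`: in an assay on membranes from brain for displacement of a labelled ligand from Sigma non-opioid intracellular receptor 1 (Cavia porcellus), read by scintillation counting, with a stated time of 120 min (a lower number here means a stronger inhibitor, a higher number a weaker inhibitor), compound 1 gives 0.51 nM.
Compound 2, `C[C@H]1CN(CCCCc2ccccc2)CCCN1Cc1ccccc1`: in this assay compound 2 gives 0.77 nM.

The two numbers sit within the usual scatter of each other, so neither compound can be called the stronger inhibitor. Compound 3, `C[C@@H]1CN(CCCCc2ccccc2)CCCN1Cc1ccccc1`, has not been measured in this assay. Compared with compound 2, (the two compounds have the same atoms and bonds and differ only in configuration as drawn: 1 of 1 stereo elements differ; a stereocentre at a saturated ring carbon is drawn S in compound 2 and R in compound 3). Among the measured compounds shown here, no measured pair shows what a change of this kind does here, so the expectation rests on compound 2 alone: a modest step, more likely toward a higher number, and possibly none beyond the scatter. The expected step of a 1.9-fold higher number from compound 2 to compound 3 (0.29 log units; within the scatter) gives compound 3 an estimated 1.5 nM, within 0.4 nM to 6 nM.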

Compound 3, inhibition constant: 0.83 nM
The estimate for compound 3 lay 1.8-fold (0.26 log units) above the measured number, and the stated range covers the measured number.
By their numbers in this assay, from the lowest: compounds 1, 2 and 3 (each within the scatter of the next).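

In this assay, inverting the stereocentre at the saturated ring carbon gives a 1.1-fold higher number from compound 2 to compound 3 (0.03 log units; within the scatter), so with the rest of the structure held fixed, the configuration drawn at this position makes no difference beyond the scatter. Compounds 1 and 2 could not show this, since they do not form a pair that differs in one place. This comparison isolates a single feature: the fact that compounds 2 and 3 differ only in the configuration as drawn

From the compounds shown here alone, whether the same holds when the other ring nitrogen carries the methoxybenzyl group of compound 1 stays open. So does the effect of replacing the methyl group on that ring carbon with an ethyl or hydroxymethyl group.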